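A few compounds are considered here, and "the series" means these few. Any claim that something is new, unique, unknown or untested is made for them only; others in the source may bear on it.

Measured so far:
compound 1, `Cn1c(=O)c(S(=O)(=O)c2ccccc2)cc2cnc(Nc3cnc4[nH]ccc4c3)nc21`, 5000 nM;
compound 2, `O=c1[nH]c2nc(Nc3ccc4[nH]ccc4c3)ncc2cc1S(=O)(=O)c1ccc(F)cc1F`, 15000 nM;
compound 3, `Cn1c(=O)c(S(=O)(=O)c2ccc(F)cc2)cc2cnc(Nc3ccc4[nH]ccc4c3)nc21`, 200 nM.

The account concerns three compounds tested in a functional assay on K562 cells (Homo sapiens) for inhibition, read by trypan blue exclusion, with a stated time of 72 h; on this read-out higher numbers stand for weaker inhibition and lower numbers for stronger inhibition. Compound 2 gives the highest number of the three, so it is the weakest inhibitor here. Compound 1 gives 5000 nM, a lower number than compound 2 by a margin beyond the scatter. Compound 3 gives 200 nM, the lowest of the three, and its gap to compound 2 is far beyond the scatter.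

The next compound, compound 4, `CCn1c(=O)c(S(=O)(=O)c2ccc(F)cc2F)cc2cnc(Nc3ccc4[nH]ccc4c3)nc21`, has not yet been measured in this assay. It differs from compound 2 in one place: ethyl in place of hydrogen on an aromatic nitrogen. Within the data shown here, no pair of measured compounds differing in just this one place is available, so the size of this step cannot be read from the data directly. Among the measured compounds shown here, what the numbers show is that compound 2, the only compound bearing hydrogen on that aromatic nitrogen, sits weakest, while compound 1 and compound 3, which carry a methyl there alongside other differences, give lower numbers.

On that basis compound 4 is expected to inhibit more strongly than compound 2, with a step from a 19-fold lower number from compound 2 to compound 4 (1.27 log units; beyond the scatter) that is estimated to be beyond the scatter. The estimate for compound 4 is 800 nM, within a range from 150 nM to 4000 nM.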

Compound 4, half-maximal inhibitory concentration: 750 nM
The estimate for compound 4 lay 1.1-fold (0.03 log units) above the measured number; low and high end bracket the measured number.
By their numbers in this assay, from the lowest: compound 3; then compound 4; then compound 1; then compound 2.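

In this assay, among these compounds, the change of hydrogen to ethyl on the aromatic nitrogen gives a 20-fold lower number from compound 2 to compound 4 (1.30 log units; beyond the scatter), a large step and the first reading of this position on its own, with the (2,4-difluorophenyl)sulfonyl group and the rest of the structure held fixed. Among the earlier compounds, the two carrying methyl there also differed elsewhere, so they could not separate this position from those other changes; this pair shows that the position alone can shift inhibition strongly and that the hydrogen on this nitrogen is not needed for activity in these cells. The compounds shown offer no evidence on why ethyl has this effect.

As far as these compounds go, it remains open whether the gain is specific to ethyl or would appear equally with methyl, a longer chain such as propyl, or a chain ending in an amine on the same nitrogen. It is also open whether a step of this size would carry over to the other sulfonyl groups and the other amine-linked bicyclic groups seen among these compounds.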